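The source may hold more compounds than are shown below. What is called first, only, known or untested is meant among the compounds shown, and "the series" means these compounds.

Working notes on the series. Among the compounds with values here, compound 1 `COC[C@H](NC1CCN(CCCc2c[nH]c3ccc(-n4cnnc4)cc23)CC1)c1ccccc1` is the reference point; in a functional assay on CHO cells for activation of 5-hydroxytryptamine receptor 1D (Homo sapiens), read by GTPgammaS binding (a higher number here means a larger maximal response, a lower number a smaller maximal response), compound 1 gives 93%, the highest of the two numbers measured so far. Compound 2 `OC[C@H](NC1CCN(CCCc2c[nH]c3ccc(-n4ccnc4)cc23)CC1)c1ccccc1` differs from compound 1 in more than one place; in this assay compound 2 gives 74%, a number lower than that of compound 1 by a margin beyond the usual scatter. Within the data shown here, no step between measured compounds differing in a single place is available, so the effect of any one change cannot be read directly from the numbers.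

Compound 3 `c1ccc2c(c1)CCC2NCC1CCN(CCCc2c[nH]c3ccc(-n4cnnc4)cc23)CC1` has not yet been measured. Relative to compound 1 it carries ((2,3-dihydro-1H-inden-1-yl)amino)methyl in place of (2-methoxy-1-phenylethyl)amino on a saturated ring carbon. Both measured compounds reach a large maximal response in this assay, so compound 3 is expected to keep a large maximal response as well. For compound 3 the expected step is a number 8 percentage points lower from compound 1 to compound 3 (within the scatter), modest in size, more likely downward than upward, and possibly within the scatter. Compound 3 is therefore expected to give about 85% in this assay, with a range from 60% to 105%.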

Compound 3, largest response reached (reported as efficacy), in percent of the reference or control that the assay uses: 78%
Compound 3: the middle estimate sits 7 percentage points above what was measured, and the stated range covers the measured number.
By their numbers in this assay, from the lowest: compounds 2 and 3 (each within the scatter of the next); then compound 1.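

In this assay, within the data shown here, putting ((2,3-dihydro-1H-inden-1-yl)amino)methyl in place of (2-methoxy-1-phenylethyl)amino on a saturated ring carbon gives a number 15 percentage points lower from compound 1 to compound 3 (beyond the scatter) and provides the first direct reading of a single change, which shows that the group at this position affects the maximal response. Compound 3 gives 78% and so keeps a large maximal response, even though the entering group has no oxygen, has no defined stereocentre and adds a five-membered non-aromatic ring of carbon only. All of these differences arrive together in one change, and no measurement on hand accounts for the step.

The compounds shown leave open which part of the change carries the step: the added methylene link, the closed ring, or the lost oxygen. A (1-phenylethyl)amino group or a benzylamino group on the same ring carbon would help to separate these parts, while the steps that would link compound 2 to the other compounds cannot be read.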